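The source may hold more compounds than are shown below. What is called first, only, known or untested is meant among the compounds shown, and "the series" means these compounds.

Three compounds share one core and differ only in the group carried on an oxygen next to a carbonyl group. Compound 1 `CCCOC(=O)Nc1ccc([Se]C#N)cc1` bears propyl there, compound 2 `CCOC(=O)Nc1ccc([Se]C#N)cc1` bears ethyl, and compound 3 `N#C[Se]c1ccc(NC(=O)Oc2ccccc2)cc1` bears phenyl. In a functional assay on HT-29 cells (Homo sapiens) for cytotoxicity, read by MTT assay, with a stated time of 72 h (on this read-out lower numbers stand for higher toxicity in this test and higher numbers for lower toxicity in this test), compound 1 gives 75400 nM, compound 2 gives 66600 nM and compound 3 gives 71700 nM. On the numbers as they stand, compound 3 has the second highest of the three values, yet all three lie within the scatter of one another.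

Compound 4 `CC(C)COC(=O)Nc1ccc([Se]C#N)cc1` is the next member, and it differs from compound 3 in this way: isobutyl in place of phenyl on an oxygen next to a carbonyl group. Going by the values given here, the steps that bear on this change are the two in which phenyl replaced an alkyl group at the same place, a 1.1-fold lower number from compound 1 to compound 3 (0.02 log units; within the scatter) and a 1.1-fold higher number from compound 2 to compound 3 (0.03 log units; within the scatter), and the lengthening of the alkyl group itself, a 1.1-fold lower number from compound 1 to compound 2 (0.05 log units; within the scatter); each of these stayed within the scatter. Among the compounds with values here, nothing measured so far suggests that the group on this oxygen moves the number beyond the scatter, so for compound 4 the expected step is a 1.0-fold lower number from compound 3 to compound 4 (0.00 log units; within the scatter). The estimate for compound 4 in this assay is therefore 71000 nM, with a range from 35000 nM to 145000 nM.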

Compound 4, concentration lethal to 50% of the cells: 63700 nM
Compound 4: middle estimate off by 1.1-fold (0.05 log units), on the high side, within the range that was stated.
By their numbers in this assay, from the lowest: compounds 4, 2, 3 and 1 (each within the scatter of the next).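

Compound 4 puts the first branched chain on this oxygen next to a carbonyl group, and branching proves to be a change that this assay does not separate from the scatter, both against the straight propyl chain, a 1.2-fold lower number from compound 1 to compound 4 (0.07 log units; within the scatter), and against the ethyl group, a 1.0-fold lower number from compound 2 to compound 4 (0.02 log units; within the scatter). The exchange of phenyl for isobutyl also takes away the six-membered aromatic ring of carbon only, and this larger alteration in the shape of the group still gives a 1.1-fold lower number from compound 3 to compound 4 (0.05 log units; within the scatter), within the scatter, so a straight chain, a branched chain and an aromatic ring all read alike at this place across these four compounds. No measurement shown here offers an explanation of why these groups give such similar numbers in this test.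

On these data alone, every group seen so far at this place is built of carbon and hydrogen alone, so it remains open whether an amine, a carboxylic acid or a much longer chain there would give a number beyond the scatter. As far as these compounds go, it is also open whether a change elsewhere on the shared core would matter more than any change at this oxygen.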